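The source may report more compounds than this note shows. Statements on the series, on what has been measured and on what is new or still open speak of the compounds shown alone.

Measured so far, in a functional assay on NUGC-3 cells (Homo sapiens) for inhibition, read by sulforhodamine B assay, with a stated time of 48 h; a lower number here means a stronger inhibitor of growth, a higher number a weaker inhibitor of growth:

compound 1 `O=C(Nc1cccc(O)c1)C1c2ccccc2CCN1C(=O)c1ccc(Cl)cc1`: > 10000 nM
compound 2 `O=C(Nc1cccc(O)c1)C1NCCc2ccccc21`: > 10000 nM

Both entries are limits of this assay, not numbers. The value of compound 2 is a limit; where it stands within this assay is therefore unknown beyond that. Within the data shown here, the one measured step, a step that the two limits leave unreadable from compound 1 to compound 2, cannot be read because both of its ends sit at the limit of > 10000 nM in this assay, at which 2 of the 2 values shown sit.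

Compound 3 `COc1cccc(NC(=O)C2NCCc3ccccc32)c1` differs from compound 2 by methyl in place of hydrogen on an oxygen on an aromatic ring. Among the measured compounds shown here, no measured step touches an oxygen on an aromatic ring, so nothing here speaks for or against a change in this assay from this replacement, and no direction can be read from the data. Given that compound 2 sits at the limit, the most that can be said is that compound 3 is expected to sit there as well, with the step that the limit leaves unreadable from compound 2 to compound 3 taken as no change beyond the scatter. The estimate for compound 3 in this assay is therefore 15000 nM, with a range from 5000 nM to 50000 nM, and the assay is most likely to report only a limit again.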

Compound 3, concentration for 50% growth inhibition: > 10000 nM
Compound 3: a limit, no number (the forecaster's own chance of this, stated with the estimate: 85%); the middle value is on the limit's open side.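

Compound 2 and compound 3 both stand as limits rather than numbers in this assay, so no new step can be read between them: the limit of > 10000 nM in this assay, at which 3 of the 3 values shown sit.

The compounds shown leave open whether hydroxy to methoxy changes growth inhibition at all, since none has yet given a number.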